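This account rests on a few compounds, and the source may have more. Where it says the series, first, only, none or still open, it means among the compounds named here.

Compound 1, `Nc1cc(N)c2nc(-c3ccccc3)c(Oc3ccc(Cl)c(Cl)c3)nc2c1`, was tested in a functional assay on UACC-62 cells (Homo sapiens) for inhibition, read by sulforhodamine B assay, with a stated time of 48 h; on this read-out higher numbers stand for lower toxicity in this test and lower numbers for higher toxicity in this test. In this assay compound 1 gives < 100000 nM, which is a limit of the assay rather than a number. Two related compounds were measured in the same way. Compound 2, `CCOC(=O)[C@H](CCC(=O)O)NC(=O)c1ccc(CNc2nc3cc(N)cc(N)c3nc2-c2ccccc2)cc1`, also reaches only a limit in this assay, < 100000 nM. Compound 3, `CCOC(=O)[C@H](CCC(=O)O)NC(=O)c1ccc(Sc2nc3cc(N)cc(N)c3nc2-c2ccccc2)cc1`, gives 87100 nM in this assay. So compound 1 can be placed only roughly: it sits at the limit of < 100000 nM in this assay, at which 2 of the 3 values shown sit, and no step between any two of the three compounds is known. Compound 4, `Nc1cc(N)c2nc(-c3ccccc3)c(Sc3ccc(F)cc3)nc2c1`, has not yet been measured in this assay. It differs from compound 1 in one place: (4-fluorophenyl)sulfanyl in place of 3,4-dichlorophenoxy on an aromatic carbon. Within the data shown here, with no measured step to lean on, no change beyond the usual scatter of this assay is expected from this exchange. The step that the limit leaves unreadable from compound 1 to compound 4 is estimated to be small. For compound 4 the expected result in this assay is 80000 nM, within a range from 40000 nM to 100000 nM, with a real chance that again only a limit is reported.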

Compound 4, concentration lethal to 50% of the cells: 60300 nM
Compound 4: the middle estimate sits 1.3-fold (0.12 log units) above what was measured; low and high end bracket the measured number.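

In this assay, among these compounds, compound 1 gives < 100000 nM which is a limit of the assay and not a number, so no step to compound 4 can be read: (the limit of < 100000 nM in this assay, at which 2 of the 4 values shown sit). Whether (4-fluorophenyl)sulfanyl in place of 3,4-dichlorophenoxy changes the result in this assay at all, and by how much, stays open with the compounds shown.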